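Silicon-linked Aryl Swap: From Bromo to Methyl

A few compounds are considered here, and "the series" means these few. Any claim that something is new, unique, unknown or untested is made for them only; others in the source may bear on it.

In a functional assay on liver (Sus scrofa) for inhibition of squalene monooxygenase (Homo sapiens), using microsomes (on this read-out higher numbers stand for weaker inhibition and lower numbers for stronger inhibition), compound 2 `CCN(C/C=C/C#CC(C)(C)C)Cc1cccc(OC[Si](C)(C)c2ccc(Br)cc2)c1` gives 210 nM, the second highest of three numbers; compound 1 `CCN(C/C=C/C#CC(C)(C)C)Cc1cccc(OC[Si](C)(C)c2ccc(Cl)cc2)c1` gives 400 nM and compound 3 `CCN(C/C=C/C#CC(C)(C)C)Cc1cccc(OC[Si](C)(C)c2ccc(C)cc2)c1` gives 120 nM, both within the scatter of compound 2. Compound 4 `CCN(C/C=C/C#CC(C)(C)C)Cc1cccc(OC[Si](C)(C)c2ccccc2C)c1` carries the change (2-methylphenyl in place of 4-bromophenyl on a silicon). Within the data shown here, the nearest measured steps are a 1.8-fold lower number from compound 2 to compound 3 (0.24 log units; within the scatter) and a 3.3-fold lower number from compound 1 to compound 3 (0.52 log units; beyond the scatter), where methyl also replaces a halogen on an aromatic carbon; no measured pair addresses 2-methylphenyl itself. Compound 4 is therefore expected to show at most a small step of a 1.2-fold lower number from compound 2 to compound 4 (0.07 log units; within the scatter) in this assay, not clearly beyond the scatter. The estimate for compound 4 is 180 nM, with a range from 70 nM to 450 nM.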

Compound 4, half-maximal inhibitory concentration: 30 nM
Beside the measured number, compound 4's estimate is 6.0-fold (0.78 log units) above it, outside the stated range (below it).
By their numbers in this assay, from the lowest: compound 4; then compounds 3, 2 and 1 (each within the scatter of the next, the first and the last beyond it).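

Moving the methyl group on the silicon-bound ring, 2-methylphenyl in place of 4-methylphenyl, gives a 4.0-fold lower number from compound 3 to compound 4 (0.60 log units; beyond the scatter) in this assay and thus shows that where the methyl sits on this ring counts for more here than the earlier swap of bromo for methyl did. The same change to 2-methylphenyl gives a 7.0-fold lower number from compound 2 to compound 4 (0.85 log units; beyond the scatter) against the bromo compound and a 13-fold lower number from compound 1 to compound 4 (1.12 log units; beyond the scatter) against the chloro compound, the largest step in the set. Nothing at hand explains this gain. The compounds shown leave open whether 2-chlorophenyl, 2-bromophenyl or 3-methylphenyl on this silicon would read like compound 4.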